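This account rests on a few compounds, and the source may have more. Where it says the series, first, only, none or still open, it means among the compounds named here.

Compound 3 `CCCNc1nc(N)c(C(=O)N=C(N)N)nc1Cl` sits with the highest of the three numbers recorded in an assay for inhibition of acid-sensing ion channel 3 (Homo sapiens), read by patch clamp, tested at 20 uM (on this read-out higher numbers stand for more inhibition at the one concentration tested (going by the name of the read-out) and lower numbers for less inhibition), where compound 3 gives 91%. Compound 1 `NC(N)=NC(=O)c1nc(Cl)c(NCc2ccccc2Cl)nc1N` is nearest, giving 90% in this assay, and the step of a number 1 percentage points higher from compound 1 to compound 3 (within the scatter) lies within the scatter, so the two cannot be ordered. Going by the values given here, compound 2 `C=CCNc1nc(N)c(C(=O)N=C(N)N)nc1Cl` is furthest, giving 78% in this assay; the step of a number 13 percentage points higher from compound 2 to compound 3 (beyond the scatter) and the step of a number 12 percentage points lower from compound 1 to compound 2 (beyond the scatter) are the only changes seen to move the number beyond the scatter.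

Compound 4 `CC(C)(C)Nc1nc(N)c(C(=O)N=C(N)N)nc1Cl` differs from compound 3 by tert-butyl in place of propyl on a nitrogen on an aromatic ring. The measured steps all vary the group carried on that same aromatic nitrogen, and they range from no change to a modest one, with no branching change among them. On that basis compound 4 is expected to stay close to compound 3, with a step of a number 6 percentage points lower from compound 3 to compound 4 (within the scatter) anticipated to fall within the scatter. The inhibition of compound 4 in this assay is therefore estimated at 85%, with a range from 70% to 95%.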

Compound 4, a percentage reported as inhibition, at one concentration (the size of the read-out at that concentration, not a potency): 48%
Beside the measured number, compound 4's estimate is 37 percentage points above it; measured number outside the range, below it.
By their numbers in this assay, from the lowest: compound 4; then compound 2; then compounds 1 and 3 (each within the scatter of the next).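

In this assay, going by these compounds alone, the step of a number 43 percentage points lower from compound 3 to compound 4 (beyond the scatter) is the largest seen at this position, and the step of a number 30 percentage points lower from compound 2 to compound 4 (beyond the scatter) runs the same way, so the group on this nitrogen can move the number much further than the earlier compounds showed. The earlier steps all changed what sits on a saturated chain carbon bound to that nitrogen, whereas tert-butyl is the only branched group among the compounds shown. Nothing given here accounts for the drop.

The compounds shown do not tell whether branching itself goes with the lower number, or the larger group, since tert-butyl differs from propyl in both. From the compounds shown here alone, an isopropyl or cyclopropyl group on the same nitrogen, or a longer straight chain such as butyl or pentyl, remains open.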